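The source may hold more compounds than are shown below. What is called first, only, known or untested is meant among the compounds shown, and "the series" means these compounds.

Measured compounds:
compound 1 `CC(C)(C(=O)O)c1nn(Cc2cn3cc(OCC4CC4)c(Cl)cc3n2)c2ccccc2c1=O`: 361 nM
compound 2 `CCC(C(=O)O)c1nn(Cc2cn3cc(OCC4CC4)c(Cl)cc3n2)c2ccccc2c1=O`: 25 nM

In a functional assay on HFL1 cells for antagonist activity at sphingosine 1-phosphate receptor 2 (Homo sapiens), read by ELISA, with a stated time of 24 h, in the presence of a further agent that is not named here (a lower number here means a stronger inhibitor, a higher number a weaker inhibitor), compound 1 `CC(C)(C(=O)O)c1nn(Cc2cn3cc(OCC4CC4)c(Cl)cc3n2)c2ccccc2c1=O` gives 361 nM. In this assay compound 2 `CCC(C(=O)O)c1nn(Cc2cn3cc(OCC4CC4)c(Cl)cc3n2)c2ccccc2c1=O` gives 25 nM. Within the data shown here, of these two numbers compound 2 has the lowest, and its only neighbour is compound 1, separated by a 14-fold lower number from compound 1 to compound 2 (1.16 log units; beyond the scatter). Compound 3 `C[C@H](C(=O)O)c1nn(Cc2cn3cc(OCC4CC4)c(Cl)cc3n2)c2ccccc2c1=O` differs from compound 2 in one place: 1-carboxyethyl in place of 1-carboxypropyl on an aromatic carbon. Among the measured compounds shown here, one measured step touches this carbon, a 14-fold lower number from compound 1 to compound 2 (1.16 log units; beyond the scatter), and it was large; but it altered the group in another way, and no measured pair shortens the chain by one carbon or sets a single stereocentre as here. That step shows this position can move the number far, yet gives no direction for the present change. The expected step is therefore a 1.4-fold higher number from compound 2 to compound 3 (0.15 log units; within the scatter), modest, inside a wide range. Compound 3 in this assay is estimated at 35 nM, between 8 nM and 150 nM.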

Compound 3, half-maximal inhibitory concentration: 19 nM
The estimate for compound 3 lay 1.8-fold (0.27 log units) above the measured number; the range from low to high includes it.
By their numbers in this assay, from the lowest: compounds 3 and 2 (each within the scatter of the next); then compound 1.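

In this assay, 1-carboxyethyl in place of 1-carboxypropyl gives a 1.3-fold lower number from compound 2 to compound 3 (0.12 log units; within the scatter), so this change on the aromatic carbon, which also brings one defined stereocentre, leaves the two numbers within the scatter of each other. The large step away from 1-carboxy-1-methylethyl now appears with a second group, as 1-carboxyethyl in place of 1-carboxy-1-methylethyl gives a 19-fold lower number from compound 1 to compound 3 (1.28 log units; beyond the scatter), so it is not tied to 1-carboxypropyl alone. No evidence is available to explain either result.

The compounds shown leave open what the mirror-image form of 1-carboxyethyl would give, and how a carboxymethyl group or a longer chain would compare at this carbon. They also leave open whether a primary amide could stand in place of the carboxylic acid.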